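The source may report more compounds than this note shows. Statements on the series, on what has been measured and on what is new or still open speak of the compounds shown alone.

Working notes on the three diphenol pyridines measured in a functional assay on DU-145 cells (Homo sapiens) for inhibition (on this read-out higher numbers stand for weaker inhibition and lower numbers for stronger inhibition), and on the next analogue.

Compound 1, `Oc1ccc(-c2cc(-c3ccccc3F)cc(-c3ccc(O)cc3)n2)cc1`: 7780 nM.
Compound 2, `Oc1ccc(-c2cc(-c3ccc(F)cc3)cc(-c3ccc(O)cc3)n2)cc1`: 6030 nM.
Compound 3, `Oc1ccc(-c2cc(-c3cccc(C(F)(F)F)c3)cc(-c3ccc(O)cc3)n2)cc1`: > 50000 nM, a limit of the assay and not a number.

Compound 3 therefore sits at the limit (the limit of > 50000 nM in this assay, at which 1 of the 3 values shown sits), above both neighbours. On these data alone, the step of an at least 6.4-fold higher number from compound 1 to compound 3 (0.80 log units; beyond the scatter) and the step of an at least 8.2-fold higher number from compound 2 to compound 3 (0.91 log units; beyond the scatter) are both beyond the scatter, whereas the step of a 1.3-fold lower number from compound 1 to compound 2 (0.11 log units; within the scatter) is within it; so only the 3-(trifluoromethyl)phenyl analogue stands apart, and it does so as a limit whose true value is unknown.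

The next analogue, compound 4, `Oc1ccc(-c2cc(-c3cccc(OC(F)(F)F)c3)cc(-c3ccc(O)cc3)n2)cc1`, differs from compound 3 by trifluoromethoxy in place of trifluoromethyl on an aromatic carbon. For the measured compounds named here, no measured step exchanges one of these two groups for the other, so no direct precedent exists. Going by the values given here, the only bearing steps are those leading into compound 3, and they show that the substituent on this ring can move the number far. With compound 3 itself at a limit, a step of a number no higher from compound 3 to compound 4 (the limit leaves the size open) in this assay is expected to be small or nil relative to the scatter. Compound 4 is therefore expected to give about 50000 nM, between 15000 nM and 150000 nM, most likely again reported as a limit.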

Compound 4, half-maximal inhibitory concentration: > 50000 nM
Compound 4 was reported as a limit; the forecaster's own chance of this, stated with the estimate: 60%; the middle value lies on the limit itself.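

In this assay compound 3 and compound 4 are both reported as limits and not as numbers, so the step between them cannot be read: the limit of > 50000 nM in this assay, at which 2 of the 4 values shown sit.

The compounds shown leave open where the true value of either compound lies, and so whether trifluoromethoxy in place of trifluoromethyl changes the read-out at all.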